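Arylpiperazine series: cyclopropyl entering on the terminal phenyl

The source may report more compounds than this note shows. Statements on the series, on what has been measured and on what is new or still open speak of the compounds shown alone.

Compound 3 `CN(C)C(=O)c1cccnc1NCCCN1CCN(c2ccccc2)CC1` gives 15.9 nM in a functional assay on aorta for antagonist activity at Alpha-1D adrenergic receptor (Rattus norvegicus) (a higher number here means weaker binding, a lower number tighter binding), the highest of the three numbers to hand. Compound 2 `COc1ccccc1N1CCN(CCCNc2ccccc2C(=O)c2ccccc2)CC1` gives 10 nM, which lies within the scatter of compound 3, while compound 1 `COc1ccccc1N1CCN(CCCNc2ncccc2C(=O)C2CC2)CC1` gives 2 nM, a gap beyond the scatter. Compound 4 `CN(C)C(=O)c1cccnc1NCCCN1CCN(c2ccccc2C2CC2)CC1` is not yet measured. Its change from compound 3 is cyclopropyl in place of hydrogen on an aromatic carbon. Within the data shown here, compounds 1 and 2 both carry a substituent on the ring that stays bare in compound 3 and both sit at lower numbers, but each also differs from compound 3 elsewhere, so no single step isolates this ring. A modest move toward lower numbers is expected, a 2.3-fold lower number from compound 3 to compound 4 (0.36 log units; beyond the scatter), not clearly beyond the scatter. Compound 4 is estimated at 7 nM, between 2.5 nM and 20 nM.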

Compound 4, dissociation constant: 63.1 nM
Compound 4: middle estimate off by 9.0-fold (0.95 log units), on the low side; measured number above the stated range.
By their numbers in this assay, from the lowest: compound 1; then compounds 2 and 3 (each within the scatter of the next); then compound 4.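

In this assay, among these compounds, cyclopropyl in place of hydrogen on this aromatic carbon gives a 4.0-fold higher number from compound 3 to compound 4 (0.60 log units; beyond the scatter) and so moves toward weaker binding, in the one step that isolates this ring. The lower numbers of compounds 1 and 2, which also carry a substituent on this ring, therefore give no support for a gain here, as both differ elsewhere too. Nothing at hand accounts for this rise. Open, going by these compounds, is whether a chlorine atom or an ethyl at this position would give the same rise, and whether methoxy on the bare ring of compound 3 would move the number in either direction.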